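The source may hold more compounds than are shown below. What is called first, only, known or untested is meant among the compounds shown, and "the series" means these compounds.

Measured set in an ADME assay on HCT-116 cells (Homo sapiens) for cytotoxicity, read by CellTiter-Glo, with a stated time of 72 h; a lower number here means a stronger inhibitor, a higher number a weaker inhibitor:
Compound 1, `CC1CCN(C2CCN(S(=O)(=O)c3ccc(OCc4ccccc4)cc3)CC2)CC1`, gives > 5000 nM, a limit of the assay.
Compound 2, `COC(=O)c1ccc(S(=O)(=O)N2CCC(N3CCC(C)CC3)CC2)cc1`, gives > 5000 nM, a limit of the assay.
Compound 3, `COc1ccc(-c2ccc(S(=O)(=O)N3CCC(N4CCC(C)CC4)CC3)cc2)cc1`, gives > 5000 nM, a limit of the assay.

Compound 3 stands at the limit of > 5000 nM in this assay, at which 3 of the 3 values shown sit, so its position is known only as a limit, and the same holds for the two other compounds. The steps between the measured compounds are therefore all unreadable: a step that the two limits leave unreadable from compound 1 to compound 2, a step that the two limits leave unreadable from compound 1 to compound 3 and a step that the two limits leave unreadable from compound 2 to compound 3. None of them gives a size, and none of them touches the substituent that changes next.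

Compound 4, `CC1CCN(C2CCN(S(=O)(=O)c3ccc(-c4ccc(Cl)cc4)cc3)CC2)CC1`, differs from compound 3 by chloro in place of methoxy on an aromatic carbon. Among the measured compounds shown here, no measured step bears on this exchange directly; the only comparisons in hand concern benzyloxy, methoxycarbonyl and 4-methoxyphenyl on the same aromatic carbon, and every one of them sits at the limit on both sides. The change from compound 3 to compound 4 is small in atom count and stays at the outer ring. With three compounds of the series all at the limit, the expectation for the step is a step that the limit leaves unreadable from compound 3 to compound 4, that is, nothing readable beyond the scatter.

Compound 4 is thus estimated at 8000 nM, within a range from 3000 nM to 30000 nM, with the result most likely reported again as a limit.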

Compound 4, half-maximal inhibitory concentration: > 5000 nM
Compound 4 gave a limit, no number (the forecaster's own chance of this, stated with the estimate: 75%); the middle value does not contradict the limit.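

In this assay compound 4 gives > 5000 nM, a limit and not a number. Among the compounds shown here, its steps from compound 1, compound 2 and compound 3 cannot be read, and no new step follows from this result: the limit of > 5000 nM in this assay, at which 4 of the 4 values shown sit. The compounds shown leave open how far these four compounds differ in this assay, and whether any substituent in this series gives a readable value there.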